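Removing One Methoxy Group on a Shared Core

This account rests on a few compounds, and the source may have more. Where it says the series, first, only, none or still open, it means among the compounds named here.

Of the compounds shown here, three built on a shared core have been tested. Compound 1 `COc1ccc(-c2cc(NC(=S)NNC(=O)c3ccc(C)cc3)cs2)cc1` gives 40000 nM in a functional assay on MCF7 cells (Homo sapiens) for inhibition, read by colorimetric assay and MTT assay, with a stated time of 72 h; on this read-out lower numbers stand for stronger inhibition and higher numbers for weaker inhibition. Compound 2 `Cc1ccc(C(=O)NNC(=S)Nc2csc(-c3ccccc3)c2)cc1` gives 30000 nM in this assay; the change from compound 1 to compound 2 is hydrogen in place of methoxy on an aromatic carbon, and it made a 1.3-fold lower number from compound 1 to compound 2 (0.12 log units; within the scatter). Compound 3 `COc1cc(C(=O)NNC(=S)Nc2csc(-c3ccccc3)c2)cc(OC)c1OC` gives 43000 nM in this assay; how its core differs from that of compound 1 is not broken down here. Compound 4 `COc1cc(OC)cc(C(=O)NNC(=S)Nc2csc(-c3ccccc3)c2)c1` has not yet been measured. It differs from compound 3 by hydrogen in place of methoxy on an aromatic carbon, the same kind of change as from compound 1 to compound 2, though here the place is also ortho to two methoxy groups. A similarly small step is expected for compound 4, a 1.2-fold lower number from compound 3 to compound 4 (0.09 log units; within the scatter), resting on the earlier step of a 1.3-fold lower number from compound 1 to compound 2 (0.12 log units; within the scatter). Compound 4 is therefore estimated at 35000 nM, with a likely range from 15000 nM to 80000 nM.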

Compound 4, half-maximal inhibitory concentration: 38000 nM
Compound 4: middle estimate off by 1.1-fold (0.04 log units), on the low side; low and high end bracket the measured number.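

Replacing a methoxy group with hydrogen gave a 1.1-fold lower number from compound 3 to compound 4 (0.05 log units; within the scatter) in this assay. Set beside the earlier case, the change looks much the same on both cores, so for these two pairs it carries over with no visible difference: the same change on two cores in this assay, a 1.3-fold lower number (0.12 log units; within the scatter) from compound 1 to compound 2 and a 1.1-fold lower number (0.05 log units; within the scatter) from compound 3 to compound 4, 1.2-fold (0.07 log units) apart, within the scatter of two such steps. This does not show that the change has a reliable effect, since neither step stands out from the scatter, and two pairs cannot say how it would behave on other cores in the series.

The compounds shown leave open whether any group other than methoxy or hydrogen at these places would move the number. An amine, a carboxylic acid or a longer chain there could answer that.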